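Butyl in place of 4-fluorophenyl on the amide carbonyl

This account rests on a few compounds, and the source may have more. Where it says the series, first, only, none or still open, it means among the compounds named here.

Of the compounds shown here, three built on one shared core have been measured in a physicochemical assay for solubility, read by HPLC; on this read-out higher numbers stand for higher solubility and lower numbers for lower solubility. Compound 1 `O=C(c1ccc(Cl)cc1)N1CCN(c2nc(=O)c3cc(C(F)(F)F)cc([N+](=O)[O-])c3s2)CC1` gives 5.19 ug/mL, compound 2 `CCC(=O)N1CCN(c2nc(=O)c3cc(C(F)(F)F)cc([N+](=O)[O-])c3s2)CC1` gives 3.29 ug/mL, and compound 3 `O=C(c1ccc(F)cc1)N1CCN(c2nc(=O)c3cc(C(F)(F)F)cc([N+](=O)[O-])c3s2)CC1` gives 1.69 ug/mL. Compound 3 stands lowest of the three: the nearest is compound 2, a difference within the scatter, and the furthest is compound 1, reached by a 3.1-fold lower number from compound 1 to compound 3 (0.49 log units; beyond the scatter).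

Compound 4 `CCCCC(=O)N1CCN(c2nc(=O)c3cc(C(F)(F)F)cc([N+](=O)[O-])c3s2)CC1` is next. It differs from compound 3 in one place: butyl in place of 4-fluorophenyl on a carbonyl carbon. Among the measured compounds shown here, two measured steps bear on this change. The step of a 1.9-fold lower number from compound 2 to compound 3 (0.29 log units; within the scatter) ran in the opposite direction and stayed within the scatter, and the step of a 1.6-fold lower number from compound 1 to compound 2 (0.20 log units; within the scatter) also stayed within the scatter. Nothing measured here separates butyl from ethyl on that carbonyl carbon. The account therefore expects the step of a 2.1-fold higher number from compound 3 to compound 4 (0.32 log units; beyond the scatter) to be small, leaning upward and not clearly beyond the scatter. Compound 4 is estimated to give 3.5 ug/mL, with a range from 1.5 ug/mL to 8 ug/mL.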

Compound 4, solubility: 42.5 ug/mL
For compound 4 the middle estimate is 12-fold (1.08 log units) below the measured one; measured number above the stated range.
By their numbers in this assay, from the lowest: compounds 3, 2 and 1 (each within the scatter of the next, the first and the last beyond it); then compound 4.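

Among the compounds shown here, at this carbonyl carbon the group carried can matter far more than the earlier compounds suggested: in this assay, the steps between ethyl and the aryl groups on this carbon stayed within the scatter, while butyl stands clear of both aryl amides (a 25-fold higher number from compound 3 to compound 4 (1.40 log units; beyond the scatter); an 8.2-fold higher number from compound 1 to compound 4 (0.91 log units; beyond the scatter)). The change from ethyl to butyl alone gives a large step (a 13-fold higher number from compound 2 to compound 4 (1.11 log units; beyond the scatter)), so among these compounds the two saturated chains do not behave alike, and the aryl-to-alkyl swap has no single effect. No measurement shown here accounts for the way butyl stands apart.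

With only ethyl and butyl as chains, the compounds shown leave open whether a longer chain such as hexyl would go further or fall back. They also leave open how a branched chain, or a butyl chain ending in an amine or a carboxylic acid, would read.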